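Ethyl urea replaces dimethylaminobenzoyl on the proline amide

The source may hold more compounds than are shown below. What is called first, only, known or untested is meant among the compounds shown, and "the series" means these compounds.

In a functional assay on U2OS cells for antagonist activity at proto-oncogene Wnt-3 (Homo sapiens), read by a luciferase reporter, with a stated time of 18 h (on this read-out lower numbers stand for an effect already at smaller amounts and higher numbers for an effect only at larger amounts of compound), compound 1 `O=C(CN1CCNCC1)N1CCC(NS(=O)(=O)c2cc(S(=O)(=O)c3ccccc3)ccc2C(F)(F)F)CC1` gives 250 nM. Compound 2 `CC(C)(C)C(=O)N1CCC[C@H]1C(=O)N1CCC(NS(=O)(=O)c2cc(S(=O)(=O)c3ccccc3)ccc2C(F)(F)F)CC1` gives 270 nM in this assay, and the step of a 1.1-fold higher number from compound 1 to compound 2 (0.03 log units; within the scatter) lies within the scatter. Compound 3 `CN(C)c1ccc(C(=O)N2CCC[C@H]2C(=O)N2CCC(NS(=O)(=O)c3cc(S(=O)(=O)c4ccccc4)ccc3C(F)(F)F)CC2)cc1` gives 830 nM, the highest of the three numbers; the step of a 3.1-fold higher number from compound 2 to compound 3 (0.49 log units; beyond the scatter) is modest but beyond the scatter, and compound 1 also sits lower than compound 3.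

Compound 4 `CCNC(=O)N1CCC[C@H]1C(=O)N1CCC(NS(=O)(=O)c2cc(S(=O)(=O)c3ccccc3)ccc2C(F)(F)F)CC1` differs from compound 3 by ethylamino in place of 4-(dimethylamino)phenyl on a carbonyl carbon. For the measured compounds named here, the measured step that bears on this is the one from compound 2 to compound 3, where a tert-butyl group on the same carbonyl carbon gave the lower number; compound 4 again carries a small group in that position, though as ethylamino rather than tert-butyl, and no measured pair shows that exact exchange. He therefore expects the number to fall back towards the range of compound 2, an estimated step of a 2.4-fold lower number from compound 3 to compound 4 (0.38 log units; beyond the scatter). For compound 4 he estimates 350 nM in this assay, in a range from 150 nM to 900 nM.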

Compound 4, half-maximal effective concentration: 90 nM
Beside the measured number, compound 4's estimate is 3.9-fold (0.59 log units) above it; measured number below the stated range.
By their numbers in this assay, from the lowest: compound 4; then compounds 1 and 2 (each within the scatter of the next); then compound 3.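

In this assay, ethylamino on this carbonyl carbon takes the number below the level shared by compounds 1 and 2, with a 3.0-fold lower number from compound 2 to compound 4 (0.48 log units; beyond the scatter) against the tert-butyl group and a 2.8-fold lower number from compound 1 to compound 4 (0.44 log units; beyond the scatter) against the (piperazin-1-yl)methyl side of the series. The earlier compounds shown here showed only a rise at this position, whereas a 9.2-fold lower number from compound 3 to compound 4 (0.96 log units; beyond the scatter) now marks ethylamino as the best of the three groups tried on this carbonyl carbon with the proline amide in place. Nothing in the data at hand explains the gain.

The compounds shown leave open whether the gain goes with the hydrogen on the ethylamino nitrogen or with its ethyl chain. Methylamino, propylamino and ethoxy on the same carbonyl carbon would separate these two readings.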